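Swapping methoxy for fluoro on an inactive urea

The source may report more compounds than this note shows. Statements on the series, on what has been measured and on what is new or still open speak of the compounds shown alone.

Compound 1 `COc1ccccc1NC(=O)Nc1nc2ccc(F)cc2s1` was examined in a functional assay on MDA-MB-231 cells (Homo sapiens) for antiproliferative activity, read by sulforhodamine B assay; a lower number here means a stronger inhibitor of growth, a higher number a weaker inhibitor of growth. In this assay compound 1 gives > 10 ug/mL, which is a limit of the assay and not a number. Compound 2 `COc1ccc2sc(NC(=O)c3ccc(C#N)cc3)nc2c1` was examined as well; in this assay compound 2 gives > 10 ug/mL, again a limit. Both results sit at the limit of > 10 ug/mL in this assay, at which 2 of the 2 values shown sit. Compound 3 `O=C(Nc1nc2ccc(F)cc2s1)Nc1ccccc1F` differs from compound 1 by fluoro in place of methoxy on an aromatic carbon. Going by the values given here, with no measured step to draw on, the expected change a step that the limit leaves unreadable from compound 1 to compound 3 is none beyond the scatter. Compound 3 is therefore estimated at about 15 ug/mL, within 5 ug/mL to 50 ug/mL.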

Compound 3, concentration for 50% growth inhibition: > 10 ug/mL
Compound 3 ended at the assay's limit; the forecaster's own chance of this, stated with the estimate: 80%; the middle value does not contradict the limit.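

Going by these compounds alone, no step from compound 1 to compound 3 can be read, since both results are limits and not numbers: the limit of > 10 ug/mL in this assay, at which 3 of the 3 values shown sit. The compounds shown leave open whether fluoro or methoxy affects growth inhibition at all.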